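Open-chain replacement of the ring amine on the aromatic carbon

The source may hold more compounds than are shown below. What is called first, only, known or untested is meant among the compounds shown, and "the series" means these compounds.

Compound 3 `CC1CCN(c2cc(C(C)(C)C)ccc2CNC(=O)C(C)c2ccc(NS(C)(=O)=O)c(F)c2)CC1` gives 0.7 nM in an assay on cells for antagonist activity at transient receptor potential cation channel subfamily V member 1 (Homo sapiens), read by FLIPR and calcium flux, with a stated time of 6 min (on this read-out lower numbers stand for stronger inhibition and higher numbers for weaker inhibition), the lowest of the three numbers shown. Compound 1 `CC(C(=O)NCc1ccc(C(C)(C)C)nc1N1CCCCCC1)c1ccc(NS(C)(=O)=O)c(F)c1` gives 0.9 nM in this assay, which lies within the scatter of compound 3. Compound 2 `CCCCCc1nc(C(C)(C)C)ccc1CNC(=O)C(C)c1ccc(NS(C)(=O)=O)c(F)c1` gives 1.9 nM in this assay. Going by the values given here, the only single-point step available, a 2.1-fold higher number from compound 1 to compound 2 (0.32 log units; beyond the scatter), exchanged a ring amine on the aromatic carbon for an open chain. Compound 4 `CC(C(=O)NCc1ccc(C(C)(C)C)cc1OCC(C)(C)C)c1ccc(NS(C)(=O)=O)c(F)c1` carries a change of the same kind: neopentyloxy in place of 4-methylpiperidin-1-yl on an aromatic carbon. On the strength of that step a modest rise in the number is expected rather than a change within the scatter. The expected step is a 2.1-fold higher number from compound 3 to compound 4 (0.33 log units; beyond the scatter). Compound 4 is therefore estimated to give 1.5 nM in this assay, with a range from 0.5 nM to 5 nM.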

Compound 4, inhibition constant: 3.8 nM
Estimate against measurement, compound 4: 2.5-fold (0.40 log units) below; the measured number falls inside the stated range.
By their numbers in this assay, from the lowest: compounds 3 and 1 (each within the scatter of the next); then compounds 2 and 4 (each within the scatter of the next).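

With neopentyloxy in place of 4-methylpiperidin-1-yl on an aromatic carbon, the rise in this assay is a 5.4-fold higher number from compound 3 to compound 4 (0.73 log units; beyond the scatter). That is a larger step than a 2.1-fold higher number from compound 1 to compound 2 (0.32 log units; beyond the scatter), so both open-chain replacements shown raise the number beyond the scatter, and neither pair goes against this. Nothing at hand accounts for the size of either step.

Still open, going by these compounds, is whether a diethylamino group on the core of compound 3 would stay close to compound 3. That would help separate the loss of the ring from the exchange of ring nitrogen for ether oxygen.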